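The source may report more compounds than this note shows. Statements on the series, on what has been measured and on what is new or still open speak of the compounds shown alone.

In a functional assay on RAW264.7 cells (Mus musculus) for inhibition, read by Griess assay, with stated times of 2 h and 24 h (a higher number here means a weaker inhibitor, a lower number a stronger inhibitor), compound 1 `COc1ccc([C@@H]2CC(=O)c3c(O)cc(OCc4cn(Cc5ccccc5F)nn4)cc3O2)cc1O` gives 7320 nM, the second highest of the three numbers. Compound 3 `COc1ccc([C@@H]2C/C(=N\O)c3c(O)cc(OCc4cn(Cc5ccccc5F)nn4)cc3O2)cc1O` gives 5710 nM and compound 2 `COc1ccc([C@@H]2C/C(=N\O)c3c(O)cc(OCc4cn(Cc5ccccc5Cl)nn4)cc3O2)cc1O` gives 13400 nM; both lie within the scatter of compound 1. For the measured compounds named here, the one measured step, a 2.3-fold lower number from compound 2 to compound 3 (0.37 log units; beyond the scatter), is fluoro in place of chloro on an aromatic carbon and does not itself cover removal of the fluoro. Compound 4 `COc1ccc([C@@H]2CC(=O)c3c(O)cc(OCc4cn(Cc5ccccc5)nn4)cc3O2)cc1O` differs from compound 1 by hydrogen in place of fluoro on an aromatic carbon. Without a step of this kind among the measured compounds, and with the three numbers lying so close, no change beyond the scatter is expected in this assay. Compound 4 is therefore estimated at 8000 nM, with a range of 3500 nM to 18000 nM. The expected step is a 1.1-fold higher number from compound 1 to compound 4 (0.04 log units; within the scatter).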

Compound 4, half-maximal inhibitory concentration: 11000 nM
Estimate against measurement, compound 4: 1.4-fold (0.14 log units) below, and the stated range covers the measured number.
By their numbers in this assay, from the lowest: compounds 3, 1, 4 and 2 (each within the scatter of the next, the first and the last beyond it).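

The change from 2-fluorobenzyl to benzyl gives a 1.5-fold higher number from compound 1 to compound 4 (0.18 log units; within the scatter) in this assay, so hydrogen and fluoro at this place on the core of compound 1 cannot be told apart here. Fluoro and chloro at the same place could be told apart, but only on the core of compound 2 and compound 3, which carries an oxime instead of the carbonyl. No measurement offered here accounts for this result.

The compounds shown leave open how a methoxy, an amine or a carboxylic acid would read at this place. They also leave open whether hydrogen in place of fluoro reads the same on the core of compound 3.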